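Swapping a nitro group for chlorine on the aryl chain

The source may hold more compounds than are shown below. What is called first, only, known or untested is meant among the compounds shown, and "the series" means these compounds.

Compound 2 `O=C(/C=C/c1cc([N+](=O)[O-])ccc1Cl)/C=C/c1ccccc1Oc1ncnc2ccc(Cl)cc12` gives 91.6% in a functional assay on MGC-803 cells (Homo sapiens) for inhibition, read by MTT assay, with a stated time of 72 h, tested at 10 uM (a higher number here means more inhibition of growth at the concentration tested, a lower number less inhibition of growth), the highest of the two values shown. Compound 1 `O=C(/C=C/c1ccc(Cl)c([N+](=O)[O-])c1)/C=C/c1ccccc1Oc1ncnc2ccc(Cl)cc12` gives 70.2% in this assay. The step of a number 21.4 percentage points higher from compound 1 to compound 2 (beyond the scatter) shows that moving chloro and nitro around the same ring shifts the read-out markedly. Compound 3 `O=C(/C=C/c1ccc(Cl)c(Cl)c1)/C=C/c1ccccc1Oc1ncnc2ccc(Cl)cc12` differs from compound 2 by 3,4-dichlorophenyl in place of 2-chloro-5-nitrophenyl on a double-bonded chain carbon bound to a double-bonded chain carbon. For the measured compounds named here, no measured step covers the loss of the nitro group, so the expectation rests loosely on the sensitivity that step revealed. A modest drop is expected, a number 16.6 percentage points lower from compound 2 to compound 3 (beyond the scatter), giving for compound 3 an estimated 75% within 50% to 92%.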

Compound 3, percent growth inhibition at one concentration: 56.7%
Compound 3: the middle estimate sits 18.3 percentage points above what was measured; the measured number falls inside the stated range.
By their numbers in this assay, from the lowest: compound 3; then compound 1; then compound 2.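

In this assay, for the compounds shown here, chloro in place of nitro on an aromatic carbon brings a number 13.5 percentage points lower from compound 1 to compound 3 (beyond the scatter), the first direct look at losing the nitro group. The change from 2-chloro-5-nitrophenyl to 3,4-dichlorophenyl brings a number 34.9 percentage points lower from compound 2 to compound 3 (beyond the scatter), so both compounds with a nitro group stand above the dichloro compound, by different margins. No evidence here explains these drops. The compounds shown leave open how an amine or a nitrile would read in place of the nitro group on this ring.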